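Swapping a morpholine amide for a dimethylamide in a pyrrolidine-nitrile

The source may hold more compounds than are shown below. What is called first, only, known or untested is meant among the compounds shown, and "the series" means these compounds.

Measured so far:
- compound 1, `N#C[C@@H]1CCCN1C(=O)[C@@H]1C[C@H](C(=O)N2CCOCC2)CN1`, gives 44% in an assay on the whole organism (plasma, strain Sprague-Dawley) for inhibition of Dipeptidyl peptidase 4 (Rattus norvegicus), with a stated time of 10 h, at a dose of 1 mg/kg by the oral route; a higher number here means more inhibition at the dose given (going by the name of the read-out), a lower number less inhibition
- compound 2, `N#C[C@@H]1CCCN1C(=O)[C@@H]1C[C@H](C(=O)N2CCCCCCC2)CN1`, has "not determined" (no result reported) in this assay
- compound 3, `CCN(CC)C(=O)[C@@H]1CN[C@H](C(=O)N2CCC[C@H]2C#N)C1`, has "not determined" (no result reported) in this assay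

Among the measured compounds shown here, compound 1 carries the only number in this set, so there is nothing to rank it against; its value in this assay stands alone, with compound 2 and compound 3 showing no result at all. For the measured compounds named here, no step between two measured compounds exists here, so the effect of changing the amide part of the shared core cannot be read from the data.

Compound 4, `CN(C)C(=O)[C@@H]1CN[C@H](C(=O)N2CCC[C@H]2C#N)C1`, differs from compound 1 in one place: dimethylamino in place of morpholin-4-yl on a carbonyl carbon. Going by the values given here, with no measured step to lean on, the expectation is a change of a number 4 percentage points lower from compound 1 to compound 4 (within the scatter) in this assay, a step not beyond the scatter, in no firm direction. Compound 4 is therefore estimated at 40% in this assay, within a range of 20% to 60%.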

Compound 4, a percentage reported as inhibition, in the whole organism at one dose (the size of the read-out at that dose, not a potency): 52%
Compound 4: middle estimate off by 12 percentage points, on the low side; measured number inside the range.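

Among the compounds shown here, replacing morpholin-4-yl with dimethylamino on this carbonyl carbon gives a number 8 percentage points higher from compound 1 to compound 4 (within the scatter) in this assay, the first step that can be read at this position. Here, a six-membered ring holding a hydrogen-bond acceptor gives way to a smaller group with no ring, and the read-out does not move beyond the usual scatter, so for this pair the ring and its oxygen are not required for inhibition to be seen at this dose and time. Nothing on hand explains this result.

Steps to compound 2 and compound 3 cannot be read, so it remains open how larger amide groups behave here. On these data alone, it is also open whether a carboxylic acid or a piperazine amide on this carbonyl carbon would keep the read-out in the same range.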